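Anilino to benzylsulfanyl exchange on the side-chain carbon

A few compounds are considered here, and "the series" means these few. Any claim that something is new, unique, unknown or untested is made for them only; others in the source may bear on it.

Measured so far in an assay on isolated protein for inhibition of long-chain fatty acid transport protein 1 (Homo sapiens); a lower number here means a stronger inhibitor, a higher number a weaker inhibitor:
compound 1 `CCn1c(CNc2ccccc2)nnc1SCC(=O)Nc1ccc(C(=O)OC)cc1` gives 540 nM
compound 2 `CCOC(=O)c1ccc(NC(=O)CSc2nnc(CNc3ccccc3)n2CC)cc1` gives 330 nM

Compound 2 holds the lowest of the two numbers, but its gap to compound 1 is small: a 1.6-fold lower number from compound 1 to compound 2 (0.21 log units; within the scatter), a change that does not rise beyond the scatter. So compound 2 cannot be called the stronger inhibitor on present data; the two stand level.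

Compound 3 `CCOC(=O)c1ccc(NC(=O)CSc2nnc(CSCc3ccccc3)n2CC)cc1` is the next step from compound 2. The change is benzylsulfanyl in place of anilino on a saturated chain carbon bound to an aromatic carbon: the amine hydrogen donor on that chain carbon is given up and a sulfur-linked benzyl arm is put in its place.

Among the measured compounds shown here, no measured step bears on this change. For the measured compounds named here, the only step available, from compound 1 to compound 2, touches the ester end of the molecule and is of a different kind, so it gives no guide to what the anilino-to-benzylsulfanyl exchange does. The expectation for this assay therefore rests on the untested assumption that the aromatic ring is retained and the loss of the donor costs little: a step of about a 1.5-fold higher number from compound 2 to compound 3 (0.18 log units; within the scatter) is expected, with wide uncertainty.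

For compound 3 the estimate in this assay is 500 nM, expected to fall between 150 nM and 1700 nM.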

Compound 3, half-maximal inhibitory concentration: 7600 nM
The estimate for compound 3 lay 15-fold (1.18 log units) below the measured number; the whole stated range lies below it.
By their numbers in this assay, from the lowest: compounds 2 and 1 (each within the scatter of the next); then compound 3.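

In this assay, benzylsulfanyl in place of anilino on a saturated chain carbon bound to an aromatic carbon gives a 23-fold higher number from compound 2 to compound 3 (1.36 log units; beyond the scatter), so this position is sensitive to the group it carries, whereas the ester change gave only a 1.6-fold lower number from compound 1 to compound 2 (0.21 log units; within the scatter). Both groups carry one six-membered aromatic ring of carbon only, so the presence of that ring alone does not hold the number near that of compound 2. No measurement on hand accounts for the size of this step.

The exchange alters several things at once: a nitrogen link with one hydrogen-bond donor gives way to a sulfur link with none, and the arm gains a carbon, so the compounds shown do not separate these changes. A benzylamino group would pair the nitrogen link with the benzyl arm and a phenylsulfanyl group would pair the sulfur link with the directly attached ring, and their numbers would show which part of the exchange tracks with the step.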